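This account rests on a few compounds, and the source may have more. Where it says the series, first, only, none or still open, it means among the compounds named here.

Compound 1 `Cc1ccc(NC(=O)Nc2nc(Nc3ccccc3)cc(Sc3c[nH]c4ccccc34)n2)cc1` carries a urea linking a 4-methylphenyl group to the shared core. In a functional assay on MDA-MB-231 cells (Homo sapiens) for inhibition, with a stated time of 72 h (on this read-out lower numbers stand for stronger inhibition and higher numbers for weaker inhibition), compound 1 gives 13400 nM. Of the two numbers recorded it is the higher, yet compound 2 `O=C(Nc1ccccc1)Nc1nc(Sc2c[nH]c3ccccc23)cc(N2CCN(Cc3ccccc3)CC2)n1`, which gives 10200 nM, sits within the scatter of it, so the two cannot be separated. Compound 3 `COc1cc(NC(=O)Nc2nc(Nc3cc(OC)cc(OC)c3)cc(Sc3c[nH]c4ccccc34)n2)cc(OC)c1` is reported only as a limit, > 50000 nM, not as a number (the limit of > 50000 nM in this assay, at which 1 of the 3 values shown sits). Compound 4 `O=C(Nc1ccccc1)Nc1nc(Nc2ccccc2)cc(Sc2c[nH]c3ccccc23)n1` differs from compound 1 in one place: hydrogen in place of methyl on an aromatic carbon. For the measured compounds named here, no measured pair shows this change, so its effect is not known from these data. The account expects no step beyond the scatter, a 1.0-fold lower number from compound 1 to compound 4 (0.01 log units; within the scatter). For compound 4 the estimate is 13000 nM, with a range from 5000 nM to 35000 nM.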

Compound 4, half-maximal inhibitory concentration: 35900 nM
The estimate for compound 4 lay 2.8-fold (0.44 log units) below the measured number; the measured number lies above the stated range.
By their numbers in this assay, from the lowest: compounds 2 and 1 (each within the scatter of the next); then compound 4. At a limit, above all of these: compound 3.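

Going from methyl to hydrogen gives a 2.7-fold higher number from compound 1 to compound 4 (0.43 log units; beyond the scatter) in this assay, so this one carbon on the ring, para to a large group, makes a measurable difference. The earlier compounds shown here could not show this, as no two of them differed in one place only. Nothing given here bears on why the number moves in this way.

On these data alone, whether chlorine, an ethyl group or an amine in place of the methyl would keep, improve or further weaken the number of compound 1 remains open. So does whether the same position on the anilino ring responds likewise.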